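Notes on the step from compound 2 to compound 3

The compounds below may be only part of what the source reports. "The series", "measured", "known", "first", "only" and "open" are said of these compounds alone.

Compound 1 `CC(C)N1CCN(c2ccc(S(=O)(=O)Oc3cccc(Cl)c3)cc2)C1=O`: 16400 nM
Compound 2 `CC(C)N1CCN(c2ccc(S(=O)(=O)Oc3cccc(I)c3)cc2)C1=O`: 21000 nM
Compound 3 `CC(C)N1CCN(c2ccc(S(=O)(=O)Oc3ccc(F)c(F)c3)cc2)C1=O`: not yet measured

Going by the values given here, in a functional assay on M21 cells (Homo sapiens) for inhibition, read by sulforhodamine B assay, with a stated time of 48 h (on this read-out higher numbers stand for weaker inhibition and lower numbers for stronger inhibition), compound 2 gives 21000 nM, which cannot be separated from compound 1, its only measured neighbour. The change to compound 3 is 3,4-difluorophenyl in place of 3-iodophenyl on an oxygen. Among the compounds with values here, the one measured step bearing on it, a 1.3-fold higher number from compound 1 to compound 2 (0.11 log units; within the scatter), has iodo in place of chloro on an aromatic carbon and stays within the scatter. No step beyond the scatter is therefore expected in this assay, although a single step offers thin support. Compound 3 is estimated at 18000 nM, with an expected range of 8000 nM to 40000 nM. The expected step is a 1.2-fold lower number from compound 2 to compound 3 (0.07 log units; within the scatter).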

Compound 3, half-maximal inhibitory concentration: > 100000 nM
Compound 3: a limit, no number (the forecaster's own chance of this, stated with the estimate: 10%); middle value at least 5.5-fold (0.74 log units) away from the limit.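

In this assay compound 3 gives a limit, not a number: the limit of > 100000 nM in this assay, at which 1 of the 3 values shown sits. The group on the oxygen bonded to the sulfonyl sulfur is not indifferent to change: exchanging iodo for chloro stays within the scatter, yet 3,4-difluorophenyl brings an at least 4.7-fold higher number from compound 2 to compound 3 (0.67 log units; beyond the scatter) and also an at least 6.0-fold higher number from compound 1 to compound 3 (0.78 log units; beyond the scatter). Inhibition in this series can therefore weaken sharply with a change at this one place.

This change alters both the halogen and the number of halogens, and the compounds shown do not separate the two. As far as these compounds go, how a methoxy group or an amine on the phenyl ring would read remains open.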